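Sulfonyl aryl exchange on the shared core: dimethyl to dichloro

The source may hold more compounds than are shown below. What is called first, only, known or untested is meant among the compounds shown, and "the series" means these compounds.

Measured so far:
compound 1, `COc1ccc2ncc(S(=O)(=O)c3ccc(C)c(Cl)c3)c(N3CCC(C)CC3)c2c1`: 85%
compound 2, `COc1ccc2ncc(S(=O)(=O)c3cc(C)cc(C)c3)c(N3CCC(C)CC3)c2c1`: 79%

In an assay on isolated protein for displacement of a labelled ligand from metabotropic glutamate receptor 5 (Homo sapiens), with a stated time of 60 min, tested at 1 uM (on this read-out higher numbers stand for more inhibition at the one concentration tested (going by the name of the read-out) and lower numbers for less inhibition), compound 1 gives 85%. In the same assay compound 2 gives 79%. Compound 2 thus holds the lower of the two numbers shown, but the only step measured so far, a number 6 percentage points lower from compound 1 to compound 2 (within the scatter), is within the scatter, so the two compounds cannot be separated on this read-out.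

Compound 3, `COc1ccc2ncc(S(=O)(=O)c3cc(Cl)cc(Cl)c3)c(N3CCC(C)CC3)c2c1`, is not yet measured. It differs from compound 2 in one place: 3,5-dichlorophenyl in place of 3,5-dimethylphenyl on a sulfonyl sulfur. Going by the values given here, the one step that bears on it is the exchange of the aryl group on the sulfonyl sulfur from compound 1 to compound 2, which also swapped a chlorine for a methyl on that ring, and that step stayed within the scatter. On that basis no step beyond the scatter is expected in this assay, in either direction. Compound 3 is therefore estimated at 80%, with a range from 62% to 93%. The step this estimate implies, a number 1 percentage points higher from compound 2 to compound 3 (within the scatter), is expected to fall inside the usual scatter.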

Compound 3, a percentage reported as inhibition, at one concentration (the size of the read-out at that concentration, not a potency): 87%
Compound 3: middle estimate off by 7 percentage points, on the low side; low and high end bracket the measured number.
By their numbers in this assay, from the lowest: compounds 2, 1 and 3 (each within the scatter of the next).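

On the sulfonyl sulfur, in this assay, the exchange of 3,5-dimethylphenyl for 3,5-dichlorophenyl amounts to a number 8 percentage points higher from compound 2 to compound 3 (within the scatter), and the exchange of 3-chloro-4-methylphenyl for 3,5-dichlorophenyl amounts to a number 2 percentage points higher from compound 1 to compound 3 (within the scatter). Together with the earlier step, this leaves three aryl groups, with two methyl groups, one chlorine and one methyl group, or two chlorines, that cannot be separated on this read-out, so within these three compounds chlorine and methyl can be exchanged on this ring without a step beyond the scatter. Nothing at hand explains why these three numbers lie so close together.

All three compounds carry two small substituents on the aryl ring and share the rest of the structure, so the result says nothing about other parts of the shared core, and a read-out at one concentration leaves any difference in potency among them open. From the compounds shown here alone, whether an aryl ring carrying a carboxylic acid, an amine or a longer chain on the sulfonyl sulfur would stay in the same range also remains open.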